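The source may hold more compounds than are shown below. What is called first, only, known or untested is meant among the compounds shown, and "the series" means these compounds.

Series notes. All compounds share the core seen in compound 1 `CCCCCCCCCCc1ccc(-c2noc(CN)n2)cc1`, which carries aminomethyl on the aromatic carbon; in an assay on HeLa cells for inhibition of sphingosine-1-phosphate transporter SPNS2 (Mus musculus), read by LC-MS, tested at 2 uM (a higher number here means more inhibition at the concentration tested (going by the name of the read-out), a lower number less inhibition), compound 1 gives 62%. Compound 2 `CCCCCCCCCCc1ccc(-c2noc(C3CCNC3)n2)cc1` bears pyrrolidin-3-yl in the same place, and in this assay compound 2 gives 26%. Compound 3 `CCCCCCCCCCc1ccc(-c2noc([C@@H]3CC[C@H](N)C3)n2)cc1` bears 3-aminocyclopentyl; in this assay compound 3 gives 38%. Compound 3 thus stands second highest of the three numbers: a number 12 percentage points higher from compound 2 to compound 3 (beyond the scatter), while a number 24 percentage points lower from compound 1 to compound 3 (beyond the scatter).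

The step to compound 4 `CCCCCCCCCCc1ccc(-c2noc(CC(O)CN)n2)cc1` is 3-amino-2-hydroxypropyl in place of 3-aminocyclopentyl on an aromatic carbon. The measured steps that bear on it are the two in which a group with no ring was exchanged for one with a ring: a number 36 percentage points lower from compound 1 to compound 2 (beyond the scatter) and a number 24 percentage points lower from compound 1 to compound 3 (beyond the scatter). Both ran downward when a ring entered, so a return to a group with no ring points upward. Among the measured compounds shown here, the 3-amino-2-hydroxypropyl group itself, with its two hydrogen-bond donors and two acceptors, has no precedent among compounds 1 to 3, so the size is uncertain. A modest upward step is expected, a number 12 percentage points higher from compound 3 to compound 4 (beyond the scatter). Compound 4 is estimated at 50% in this assay, within the range 30% to 68%.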

Compound 4, a percentage reported as inhibition, at one concentration (the size of the read-out at that concentration, not a potency): 59%
For compound 4 the middle estimate is 9 percentage points below the measured one, and the stated range covers the measured number.
By their numbers in this assay, from the lowest: compound 2; then compound 3; then compounds 4 and 1 (each within the scatter of the next).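

In this assay, moving away from the ring restores the read-out: the exchange of 3-aminocyclopentyl for 3-amino-2-hydroxypropyl gives a number 21 percentage points higher from compound 3 to compound 4 (beyond the scatter) and the exchange of pyrrolidin-3-yl for the same group gives a number 33 percentage points higher from compound 2 to compound 4 (beyond the scatter) as the result. Set against aminomethyl, the extension with 2-amino-1-hydroxyethyl in place of amino gives a number 3 percentage points lower from compound 1 to compound 4 (within the scatter) and so leaves no readable change, which shows that this position, on an aromatic carbon next to the ring nitrogen and the ring oxygen, accepts a larger chain with a hydroxyl group as well as the small aminomethyl group. Across the four compounds, the two with no ring in this group, compound 1 and compound 4, lie within the scatter of each other, the two with a ring, compound 2 and compound 3, both lie lower, and no compound shown goes against this split.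

No supporting evidence bears on why the compounds with a ring and those without separate in this way. From the compounds shown here alone, what a 3-aminopropyl chain without the hydroxyl group, a longer amine chain or a carboxylic acid would give at this position remains open, so the separate contributions of the hydroxyl group and of chain length to compound 4 cannot yet be told apart.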